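A 1H-indol-3-yl group on the chain of compound 1

The source may report more compounds than this note shows. Statements on the series, on what has been measured and on what is new or still open speak of the compounds shown alone.

Within the data shown here, in an ADME assay on MRC5 cells (Homo sapiens) for cytotoxicity, read by neutral red uptake, with a stated time of 24 h (a higher number here means a weaker inhibitor, a lower number a stronger inhibitor), compound 1 (`CCCC(=O)Oc1c(C(C)C)cc2c3c1OC(=O)[C@@]31CCCC(C)(C)[C@@H]1CC2`) gives 44400 nM, the only true number so far. Compound 2 (`CCCCCCCC/C=C/CCCCCCCC(=O)Oc1c(C(C)C)cc2c3c1OC(=O)[C@@]31CCCC(C)(C)[C@@H]1CC2`) reaches only a limit, > 1000000 nM. Compound 3 (`CC(C)c1cc2c3c(c1OC(=O)CCCc1c[nH]c4ccccc14)OC(=O)[C@@]31CCCC(C)(C)[C@@H]1CC2`) carries a change from compound 1: 1H-indol-3-yl in place of hydrogen on a saturated chain carbon, three bonds along the chain from a carbonyl carbon, which puts 1H-indol-3-yl in place of hydrogen on a saturated chain carbon, three bonds along the chain from a carbonyl carbon. Among the measured compounds shown here, no measured step covers this change. In this assay a moderate move toward weaker inhibition, beyond the scatter, is expected, on the evidence of compound 2 at its limit of > 1000000 nM. The estimated step is a 2.5-fold higher number from compound 1 to compound 3 (0.39 log units; beyond the scatter). For compound 3 the expected value is 110000 nM, within an estimated range of 30000 nM to 500000 nM.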

Compound 3, half-maximal inhibitory concentration: 54500 nM
Compound 3: middle estimate off by 2.0-fold (0.30 log units), on the high side; measured number inside the range.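

In this assay, 1H-indol-3-yl in place of hydrogen on a saturated chain carbon, three bonds along the chain from a carbonyl carbon, gives a 1.2-fold higher number from compound 1 to compound 3 (0.09 log units; within the scatter) and so leaves the number effectively unchanged. Among these compounds, this position therefore accepts a large two-ring aromatic group without a shift beyond the scatter, which the earlier compounds could not show. Compound 2 gives only a limit, not a number: the limit of > 1000000 nM in this assay, at which 1 of the 3 values shown sits.

From the compounds shown here alone, whether an amine or a carboxylic acid at this chain carbon would behave the same remains open. So does whether 1H-indol-3-yl on a longer chain would.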